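Fluorophenyl to Dichlorophenyl: An Expectation on Cytotoxicity

The source may report more compounds than this note shows. Statements on the series, on what has been measured and on what is new or still open speak of the compounds shown alone.

Compound 2 `O=C(/C=C\c1cccc(F)c1)N1N=C(c2ccncc2)OC1c1c[nH]c2ccccc12` in an ADME assay on HeLa cells (Homo sapiens) for cytotoxicity, read by MTT assay, with a stated time of 72 h (a lower number here means a stronger inhibitor of growth, a higher number a weaker inhibitor of growth), gives > 30 ug/mL, which is a limit of the assay rather than a number. Compound 1 `Cc1ccc(/C=C\C(=O)N2N=C(c3ccncc3)OC2c2c[nH]c3ccccc23)cc1` in this assay likewise gives > 30 ug/mL, again a limit. The step that the two limits leave unreadable from compound 1 to compound 2 is thus not readable, and both values sit at the limit of > 30 ug/mL in this assay, at which 2 of the 2 values shown sit. Compound 3 `O=C(/C=C\c1ccc(Cl)cc1Cl)N1N=C(c2ccncc2)OC1c1c[nH]c2ccccc12` carries the change (2,4-dichlorophenyl in place of 3-fluorophenyl on a double-bonded chain carbon bound to a double-bonded chain carbon). Within the data shown here, no measured step bears readably on this change, so compound 3 is expected to remain near the limit, the step that the limit leaves unreadable from compound 2 to compound 3 expected to lie within the scatter. The estimate for compound 3 in this assay is 40 ug/mL, between 15 ug/mL and 100 ug/mL.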

Compound 3, concentration for 50% growth inhibition: 29.3 ug/mL
Compound 3: middle estimate off by 1.4-fold (0.14 log units), on the high side, within the range that was stated.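

With 2,4-dichlorophenyl on a double-bonded chain carbon bound to a double-bonded chain carbon, compound 3 alone among those shown gives a readable number in this assay rather than a limit. Its steps are floors only, an at least 1.0-fold lower number from compound 2 to compound 3 (0.01 log units; that floor lies within the scatter) and an at least 1.0-fold lower number from compound 1 to compound 3 (0.01 log units; that floor lies within the scatter) and so neither shows a change beyond the scatter. The other values remain limits: the limit of > 30 ug/mL in this assay, at which 2 of the 3 values shown sit.

As far as these compounds go, how far compound 1 and compound 2 truly lie from compound 3 stays open. So does whether an aminophenyl or a carboxyphenyl group in this place would give a clearly lower number.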